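Working notes: from compound 2 to compound 3

A few compounds are considered here, and "the series" means these few. Any claim that something is new, unique, unknown or untested is made for them only; others in the source may bear on it.

- compound 1 `Cc1ncc([N+](=O)[O-])n1CCSc1nnc(-c2ccccc2[N+](=O)[O-])o1`: 700 nM
- compound 2 `Cc1ncc([N+](=O)[O-])n1CCSc1nnc(-c2ccccc2F)o1`: 3700 nM

Within the data shown here, in a functional assay on HepG2 cells (Homo sapiens) for cytotoxicity, read by MTT assay, with a stated time of 48 h (a lower number here means a stronger inhibitor, a higher number a weaker inhibitor), compound 2 stands at 3700 nM, the higher of the two numbers measured so far. Compound 3 `Cc1ccc(-c2nnc(SCCn3c([N+](=O)[O-])cnc3C)o2)c(O)c1` is the next to be read. It carries 2-hydroxy-4-methylphenyl in place of 2-fluorophenyl on an aromatic carbon of the five-membered aromatic ring with 2 nitrogen and 1 oxygen: 2-hydroxy-4-methylphenyl in place of 2-fluorophenyl on an aromatic carbon.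

Among the measured compounds shown here, only one measured step bears on this change, and only loosely. This is a 5.3-fold higher number from compound 1 to compound 2 (0.72 log units; beyond the scatter), a modest step beyond the scatter, with fluoro in place of nitro on an aromatic carbon. It shows that a change on this aromatic ring can shift the number in this assay. For the measured compounds named here, no measured compound carries 2-hydroxy-4-methylphenyl, so the data do not fix a direction. A step no larger than that one is expected, with a slight lean towards a lower number. The estimated change is a 1.5-fold lower number from compound 2 to compound 3 (0.17 log units; within the scatter). For compound 3 the expected value is 2500 nM, with an estimated range of 700 nM to 9000 nM.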

Compound 3, half-maximal inhibitory concentration: 16600 nM
The estimate for compound 3 lay 6.6-fold (0.82 log units) below the measured number; the whole stated range lies below it.
By their numbers in this assay, from the lowest: compound 1; then compound 2; then compound 3.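

Notes on the series: replacing 2-fluorophenyl with 2-hydroxy-4-methylphenyl gives a 4.5-fold higher number from compound 2 to compound 3 (0.65 log units; beyond the scatter) in this assay. The position on an aromatic carbon of the five-membered aromatic ring with 2 nitrogen and 1 oxygen therefore responds to a change of the whole aryl group, and not only to the exchange of nitro for fluoro seen in a 5.3-fold higher number from compound 1 to compound 2 (0.72 log units; beyond the scatter). Among these compounds, compound 3 also brings the first aryl group in this short series with 1 hydrogen-bond donor and 1 hydrogen-bond acceptor, and it has the highest number of the three compounds, but no measurement at hand explains the rise.

The compounds shown leave open whether the hydroxy or the methyl accounts for the step, as both enter together; a 2-hydroxyphenyl group and a 4-methylphenyl group at this place would separate the two. Also open, on these data alone, is which way the number would move with an amine or a carboxylic acid on this phenyl ring.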